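The source may report more compounds than this note shows. Statements on the series, on what has been measured and on what is new or still open speak of the compounds shown alone.

Of the compounds shown here, three that share one core have been tested in an ADME assay on HCT-116 cells (Homo sapiens) for cytotoxicity, read by CellTiter-Glo, with a stated time of 72 h; a higher number here means a weaker inhibitor, a lower number a stronger inhibitor. Compound 1 `Cc1noc(C)c1S(=O)(=O)N1CCC(N2CCC(C)CC2)CC1` gives > 10000 nM, which is a limit and not a number. Compound 2 `CC1CCN(C2CCN(S(=O)(=O)c3cnc(Cl)s3)CC2)CC1` gives > 10000 nM, again a limit. Compound 3 `COc1cccc(S(=O)(=O)N2CCC(N3CCC(C)CC3)CC2)c1` gives > 5000 nM, so it too stands only at a limit.

Compound 4 `COc1ccc(S(=O)(=O)N2CCC(N3CCC(C)CC3)CC2)cc1OC` differs from compound 3 by a single change, methoxy in place of hydrogen on an aromatic carbon, ortho to a methoxy group and para to a large group.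

The measured steps that bear on this change alter the group on the sulfonyl sulfur. They are a step that the two limits leave unreadable from compound 1 to compound 3 and a step that the two limits leave unreadable from compound 2 to compound 3. Neither has a readable size, so they offer no number to carry over. On those two steps, no change beyond the scatter is expected in this assay, and another limit is the likely report. The expected change is a step that the limit leaves unreadable from compound 3 to compound 4. For compound 4 the estimated value is 8000 nM, with an expected range from 3000 nM to 20000 nM.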

Compound 4, half-maximal inhibitory concentration: > 5000 nM
Compound 4 ended at the assay's limit; the forecaster's own chance of this, stated with the estimate: 80%; the middle value does not contradict the limit.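

Compound 3 and compound 4 both end at a limit of the assay in this assay, so the step between them cannot be read. The compounds shown leave open whether methoxy in place of hydrogen on an aromatic carbon changes the result at all.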